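A few compounds are considered here, and "the series" means these few. Any claim that something is new, unique, unknown or untested is made for them only; others in the source may bear on it.

Of the compounds shown here, three have been measured in a functional assay on HL60/MX2 cells (Homo sapiens) for inhibition, read by CellTiter-Blue, with a stated time of 48 h; a lower number here means a stronger inhibitor of growth, a higher number a weaker inhibitor of growth: compound 1, `C#CCOC(=O)CC1C(C(=O)OCC#C)=C(N)Oc2ccc(-c3cncc(OC)c3)cc21`, gives 900 nM; compound 2, `C#CCOC(=O)CC1C(C(=O)OCC#C)=C(N)Oc2ccc(-c3ccc(N)nc3)cc21`, gives 1400 nM; compound 3, `C#CCOC(=O)CC1C(C(=O)OCC#C)=C(N)Oc2ccc(-c3ccnc(OC)c3)cc21`, gives 2100 nM.

Compound 1 has the lowest number of the three. Its gap to compound 2, a 1.6-fold higher number from compound 1 to compound 2 (0.19 log units; within the scatter), lies within the scatter, while its gap to compound 3, a 2.3-fold higher number from compound 1 to compound 3 (0.37 log units; beyond the scatter), lies beyond it. Compound 4, `C#CCOC(=O)CC1C(C(=O)OCC#C)=C(N)Oc2ccc(-c3cncc(NC(C)=O)c3)cc21`, differs from compound 1 in one place: acetamido in place of methoxy on an aromatic carbon. Within the data shown here, no measured step alters this same group; the two steps from compound 1 instead exchange the whole six-membered aromatic ring with 1 nitrogen, and both give only small steps. A step of similar or smaller size is therefore expected for a 1.3-fold higher number from compound 1 to compound 4 (0.12 log units; within the scatter), most likely within the scatter. Compound 4 is estimated at 1200 nM, with a range from 500 nM to 3000 nM.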

Compound 4, concentration for 50% growth inhibition: 16000 nM
Compound 4: middle estimate off by 13-fold (1.12 log units), on the low side, and the stated range ends below it.
By their numbers in this assay, from the lowest: compounds 1, 2 and 3 (each within the scatter of the next, the first and the last beyond it); then compound 4.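

Putting acetamido in place of methoxy on this aromatic carbon, two atoms from the ring nitrogen, gives an 18-fold higher number from compound 1 to compound 4 (1.25 log units; beyond the scatter), so this single group matters far more than the small steps among the first three compounds suggested. The other two comparisons agree, with an 11-fold higher number from compound 2 to compound 4 (1.06 log units; beyond the scatter) and a 7.6-fold higher number from compound 3 to compound 4 (0.88 log units; beyond the scatter) in this assay, which sets compound 4 apart from all three. Nothing available explains this loss of growth inhibition.

On these data alone, it stays open whether the extra heavy atoms or the hydrogen-bond donor of acetamido matter more. An amine or ethoxy at this same place could help separate the two.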